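Aryl ether variation on the shared core

The source may hold more compounds than are shown below. What is called first, only, known or untested is meant among the compounds shown, and "the series" means these compounds.

Among the measured compounds shown here, compound 1 `COc1ccccc1OC1CCN(c2ccc(-n3ccnc3)nn2)CC1` is the weaker of the two compounds measured so far. In an assay on microsomes from liver for inhibition of acyl-CoA desaturase 1 (Rattus norvegicus) (on this read-out lower numbers stand for stronger inhibition and higher numbers for weaker inhibition), compound 1 gives 543 nM, the highest of the two numbers. For the measured compounds named here, compound 2 `Oc1nnc(-c2ccc(N3CCC(Oc4ccccc4C(F)(F)F)CC3)nn2)s1` differs from compound 1 in more than one place, so no single step connects them; in this assay compound 2 gives 6.1 nM, and the two values lie far apart, well beyond the scatter. Nothing in the measured pair isolates the aryl ether position.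

Compound 3 `CCc1cccc(OC2CCN(c3ccc(-n4ccnc4)nn3)CC2)c1` keeps the core of compound 1 and changes only the aryl group: 3-ethylphenyl in place of 2-methoxyphenyl on an oxygen on a saturated carbon. Going by the values given here, no measured pair shows this change alone, so the size of its step cannot be read from the data. The expectation is a small step, within the usual scatter, with no firm direction, so that the estimated step from compound 1 to compound 3 in this assay is a 1.4-fold lower number from compound 1 to compound 3 (0.13 log units; within the scatter). Compound 3 is estimated at 400 nM, with a range of 120 nM to 1400 nM.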

Compound 3, half-maximal inhibitory concentration: 38 nM
Beside the measured number, compound 3's estimate is 11-fold (1.02 log units) above it; measured number outside the range, below it.
By their numbers in this assay, from the lowest: compound 2; then compound 3; then compound 1.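

In this assay the aryl group on the oxygen on a saturated carbon turns out to be a sensitive place: with the rest of the core of compound 1 untouched, the change gives a 14-fold lower number from compound 1 to compound 3 (1.16 log units; beyond the scatter) and the lower number lies well beyond the scatter. Among the compounds shown here, compound 1 and compound 2 differ in more than one place, so this is the first step that isolates the aryl ether position, and it comes with 8 heavy atoms on both sides, the entering 3-ethylphenyl having 0 hydrogen-bond acceptors against 1 for the leaving 2-methoxyphenyl. Nothing on hand accounts for the size of this step.

Since 2-methoxyphenyl and 3-ethylphenyl differ both in the group and in where it stands on the aryl ring, the compounds shown do not separate those two changes. As far as these compounds go, it also remains open whether a longer chain, an amine or a carboxylic acid on the aryl group would hold the number at this level or lose it again.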